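The compounds below may be only part of what the source reports. "The series", "measured", "known", "first", "only" and "open" are said of these compounds alone.

Compound 1 `Cc1cccc(N(C)c2cc(Nc3cccc(C(=O)N(CC(C)C)CC(C)C)c3)ncn2)c1` was measured in an assay on isolated protein for inhibition of calcium/calmodulin-dependent protein kinase type II subunit alpha (Homo sapiens), read by HTRF, tested at 10 uM (a higher number here means more inhibition at the concentration tested (going by the name of the read-out), a lower number less inhibition), where compound 1 gives 0%. Two further compounds were measured in this assay alongside it: compound 2 `Cc1cccc(Oc2ccnc(N3CCN(C(=O)c4c(C)noc4C)CC3)n2)c1` gives 0%, and compound 3 `CN(CCCn1ccnc1)C(=O)[C@@H]1CCCN1c1nccc(Nc2ccccc2)n1` gives 0%. Compound 1 therefore stands level with compound 2 and with compound 3 at the digits shown, and the differences among the three lie within the usual scatter of this kind of measurement.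

Compound 4 `Cc1cccc(N(C)c2cc(Nc3cccc(C(=O)N4CCCC5CCCCC54)c3)ncn2)c1` has not yet been measured. It differs from compound 1 in one place: a group of 10 heavy atoms (9 carbon, 1 nitrogen; one six-membered non-aromatic ring of carbon only, one six-membered non-aromatic ring with 1 hetero atom) in place of a group of 9 heavy atoms (8 carbon, 1 nitrogen; no ring), on a carbonyl carbon. Among the measured compounds shown here, no step between two measured compounds is available to size such a change. Because compound 1 gives 0% and the other measured compounds sit at the same level, the expected step of no change at the digits printed from compound 1 to compound 4 (within the scatter) is none beyond the scatter. Compound 4 is estimated to give 0% in this assay, with a range from -10% to 15%.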

Compound 4, a percentage reported as inhibition, at one concentration (the size of the read-out at that concentration, not a potency): 0%
Beside the measured number, compound 4's estimate shows no gap at the digits printed; the range from low to high includes it.
By their numbers in this assay, from the lowest: compounds 1, 2, 3 and 4 (each within the scatter of the next).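

In this assay, replacing the open-chain diisobutylamino with a group of two six-membered rings on the carbonyl carbon gives no change at the digits printed from compound 1 to compound 4 (within the scatter). So at this position, a ring-containing group of similar size does not bring inhibition into view, although compound 1 and compound 4 both sit at the bottom of the read-out, where any loss would stay hidden. No measurement here offers an explanation for this result.

Still open, on these data alone, is whether any group at this position can produce inhibition. A smaller amine such as dimethylamino, or a piperazine, could test this.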